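The source may hold more compounds than are shown below. What is called first, only, known or untested is meant among the compounds shown, and "the series" means these compounds.

Working notes on the series. In a functional assay on HEK293 cells with D(4) dopamine receptor (Homo sapiens) as the target, read by FLIPR (a lower number here means a smaller maximal response, a higher number a larger maximal response), compound 1 `O/N=C(\CCN1CCN(c2ccccn2)CC1)c1ccc(F)cc1` gives 74% and compound 2 `CCO/N=C(\CCN1CCN(c2cccc(OC)c2)CC1)c1ccccc1` gives 30%; compound 2 thus stands lowest of the two numbers, with compound 1 higher by a margin beyond the usual scatter. Among the compounds with values here, the two compounds differ in more than one place, so no single step is drawn between them. Compound 3 `CCO/N=C(\CCN1CCN(c2nccs2)CC1)c1ccccc1` differs from compound 2 by 1,3-thiazol-2-yl in place of 3-methoxyphenyl on an amine nitrogen in a ring. Within the data shown here, no measured step covers this kind of change, so only a modest rise in this assay is expected, the step of a number 15 percentage points higher from compound 2 to compound 3 (beyond the scatter) being uncertain in direction. Compound 3 is estimated at 45%, within 20% to 70%.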

Compound 3, largest response reached (reported as efficacy), in percent of the reference or control that the assay uses: 72%
The estimate for compound 3 lay 27 percentage points below the measured number; the whole stated range lies below it.
By their numbers in this assay, from the lowest: compound 2; then compounds 3 and 1 (each within the scatter of the next).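

In this assay, 1,3-thiazol-2-yl in place of 3-methoxyphenyl on an amine nitrogen in a ring gives a number 42 percentage points higher from compound 2 to compound 3 (beyond the scatter). Within the data shown here, this is the first single-place step, and it shows that the group at this position alone can shift the maximal response by a large amount while the rest of the structure stays fixed. No available data explain the size of this step.

Whether ring size, the hetero atoms or the smaller heavy-atom count accounts for the step remains open. So does whether 1,3-oxazol-2-yl or a plain phenyl at this position would give a comparable response.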